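Urea series: isoquinolin-1-yl to aza analogue, potency outlook

The compounds below may be only part of what the source reports. "The series", "measured", "known", "first", "only" and "open" are said of these compounds alone.

Working notes. The shared core carries a urea whose far nitrogen bears a bicyclic aromatic group, and this group is where the three measured compounds differ. Compound 1 `CC1CCN(c2nc(C(F)(F)F)ccc2CNC(=O)Nc2ccc3ccccc3n2)CC1` gives "not active" (no number reported) in an assay on isolated protein for antagonist activity at transient receptor potential cation channel subfamily V member 1 (Homo sapiens), read by FLIPR (a lower number here means a stronger inhibitor, a higher number a weaker inhibitor), and no number was reported for it. Among the measured compounds shown here, compound 2 `CC1CCN(c2nc(C(F)(F)F)ccc2CNC(=O)Nc2ccc3cccnc3c2)CC1` gives 7.1 nM in this assay and is the only member with a reported value. Compound 3 `CC1CCN(c2nc(C(F)(F)F)ccc2CNC(=O)Nc2nccc3ccccc23)CC1` gives "not active" (no number reported) in this assay, again with no number attached. So compound 3 stands among the two members for which the readout gave no figure, and it cannot be placed on a numerical scale against compound 2.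

The next step is compound 4 `CC1CCN(c2nc(C(F)(F)F)ccc2CNC(=O)Nc2nccc3cccnc23)CC1`, which differs from compound 3 as follows: a group of 10 heavy atoms (8 carbon, 2 nitrogen; 2 six-membered aromatic rings with 1 hetero atom each) in place of a group of 10 heavy atoms (9 carbon, 1 nitrogen; one six-membered aromatic ring of carbon only, one six-membered aromatic ring with 1 hetero atom), on an amide-type nitrogen. For the measured compounds named here, no measured pair of this kind exists in the set, so the size of the step cannot be read from the data. Two of the three bicyclic groups tried gave no reportable figure, and only compound 2 gave a number; the change from compound 3 to compound 4 is small in atom count, so the most likely outcome is again weak or unreported activity, with a modest chance of a measurable value. Compound 4 is estimated at 3000 nM in this assay, with an expected range from 200 nM to 30000 nM.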

Compound 4, inhibition constant: "not active" (no number reported)
Nothing numeric was reported for compound 4; there is nothing to compare the estimate with.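

No new step can be read between compound 3 and compound 4, since neither carries a number. No evidence on hand bears on this result. The compounds shown leave open how far compound 3 and compound 4 lie from compound 2, and which feature of the bicyclic group separates a reported value from none.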